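The source may hold more compounds than are shown below. What is called first, only, known or untested is meant among the compounds shown, and "the series" means these compounds.

The series in question was examined in a functional assay on DU-145 cells (Homo sapiens) for inhibition, read by trypan blue exclusion, with a stated time of 96 h (a higher number here means a weaker inhibitor of growth, a lower number a stronger inhibitor of growth), where three compounds have so far been measured. Compound 1 `Cc1ccc(CS(=O)(=O)/C(=C/c2c[nH]c3ccc(Br)cc23)C(=O)c2ccc(Cl)cc2)cc1` gives 10000 nM in this assay. Compound 3 `O=C(/C(=C\c1ccc(O)c([N+](=O)[O-])c1)SCc1ccccc1Cl)c1ccc(Cl)cc1` gives 10000 nM in this assay, so compound 1 stands level with compound 3 at the digits shown, the two together holding the highest numbers of the three. Among the measured compounds shown here, compound 2 `O=C(O)c1ccc(C(=O)/C(=C\c2ccc(Br)c([N+](=O)[O-])c2)SCc2ccc(Br)cc2)cc1`, by contrast, gives 1000 nM in this assay, a lower number than that of compound 1 and beyond the usual scatter; no single-point step links compound 2 to either of the others, so their values can only be set side by side.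

The unmeasured compound 4 `Cc1ccc(CS(=O)(=O)/C(=C/c2cc(C)cc(C)c2)C(=O)c2ccc(Cl)cc2)cc1` differs from compound 1 in one place: 3,5-dimethylphenyl in place of 5-bromo-1H-indol-3-yl on a double-bonded chain carbon bound to a double-bonded chain carbon. The core of compound 1 is otherwise kept. For the measured compounds named here, no measured pair in this set follows the same change, so there is no direct precedent for its size or direction. Compound 1 already sits at the weak end of what has been measured, and compound 4 is expected to stay near it, with a step from compound 1 to compound 4 of no change at the digits printed from compound 1 to compound 4 (within the scatter) that is not expected to exceed the scatter. Compound 4 is therefore estimated at 10000 nM in this assay, within a range of 3000 nM to 30000 nM.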

Compound 4, concentration for 50% growth inhibition: 10000 nM
Compound 4: the middle estimate sits on the measured number at the digits printed, and the stated range covers the measured number.
By their numbers in this assay, from the lowest: compound 2; then compounds 1, 3 and 4 (each within the scatter of the next).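

In this assay, among the compounds shown here, the exchange of 5-bromo-1H-indol-3-yl for 3,5-dimethylphenyl on a double-bonded chain carbon bound to a double-bonded chain carbon gives no change at the digits printed from compound 1 to compound 4 (within the scatter) and supplies the first comparison in the set between compounds that differ in one place. The five-membered aromatic ring, the ring nitrogen with its hydrogen-bond donor and the bromine can therefore all leave together without a change in the number that can be told from the scatter, although this says nothing about what each would do alone and applies only where compound 4 reads 10000 nM in this weak range. No measurement at hand accounts for this outcome.

As far as these compounds go, both groups compared at this place are aromatic, so it remains open whether a primary amine or a longer alkyl chain on that carbon would move the number at all. From the compounds shown here alone, it is also open whether the same exchange would read alike on a more active background such as that of compound 2, which gives 1000 nM in this assay and carries a carboxylic acid and a nitro group on a different core.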